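Series notes: five-membered ring swap on the ether chain

A few compounds are considered here, and "the series" means these few. Any claim that something is new, unique, unknown or untested is made for them only; others in the source may bear on it.

Measured so far:
compound 1 `O=C1OCCN1CCOc1nn(-c2ccccc2F)c2ccc(F)cc12` — 683 mL/min/kg
compound 2 `CC(C)(C)OC(=O)N1CCN(c2cccc3c2cnn3-c2ccccc2F)C1=O` — 98.3 mL/min/kg

In an ADME assay on liver for metabolic stability, with Liver microsome (Homo sapiens) as the target, using microsomes and NADPH, with a stated time of 30 min, tested at 0.5 uM (on this read-out higher numbers stand for fast clearance and lower numbers for slow clearance), compound 1 gives 683 mL/min/kg, the highest of the two numbers in hand. Among the measured compounds shown here, the only other measured compound is compound 2, which in this assay gives 98.3 mL/min/kg; the two values show compound 1 well above compound 2, a gap beyond the usual scatter, but the two structures differ in several places at once and no single step links them.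

Compound 3 `O=c1[nH]ccn1CCOc1nn(-c2ccccc2F)c2ccc(F)cc12` has not yet been measured in this assay. It differs from compound 1 as follows: a group of 6 heavy atoms (3 carbon, 2 nitrogen, 1 oxygen; one five-membered aromatic ring with 2 hetero atoms) in place of a group of 6 heavy atoms (3 carbon, 1 nitrogen, 2 oxygen; one five-membered non-aromatic ring with 2 hetero atoms), on a saturated chain carbon, two bonds along the chain from an oxygen on an aromatic ring. For the measured compounds named here, no measured pair covers a change of this kind, so nothing fixes the size of the step. The working expectation is a step of a 1.4-fold lower number from compound 1 to compound 3 (0.14 log units; within the scatter), a small drop that may not clear the scatter, with the fast clearance of compound 1 largely kept.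

Compound 3 is therefore estimated to give 500 mL/min/kg in this assay, with a range from 250 mL/min/kg to 1000 mL/min/kg.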

Compound 3, clearance: 200 mL/min/kg
Compound 3: the middle estimate sits 2.5-fold (0.40 log units) above what was measured; measured number below the stated range.
By their numbers in this assay, from the lowest: compound 2; then compound 3; then compound 1.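

Series notes, continued: at the place on a saturated chain carbon, two bonds along the chain from an oxygen on an aromatic ring, the choice of five-membered ring matters in this assay, and the swap of 2-oxo-1,3-oxazolidin-3-yl for the five-membered aromatic ring with 2 hetero atoms gives a 3.4-fold lower number from compound 1 to compound 3 (0.53 log units; beyond the scatter). Among the compounds shown here, this is the first step that can be read at a single place, and it shows that a change keeping the same number of heavy atoms in the group can still move clearance beyond the usual scatter. No measurement on these compounds accounts for the step.

The compounds shown leave open whether the step goes with the aromatic ring or with the hydrogen-bond donor that enters with it, since both change together between compound 1 and compound 3. A methyl group in place of the ring hydrogen of compound 3, or a longer chain carrying the same ring, would show how far the step holds.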